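The compounds below may be only part of what the source reports. "The series", "measured", "known", "first", "only" and "open" are said of these compounds alone.

Compound 3 `Nc1nc(NCCNc2ncc(-c3ncc[nH]3)c(-c3ccc(Cl)cc3)n2)ccc1[N+](=O)[O-]` is the starting point for this step in an ADME assay on microsomes from liver (Canis lupus familiaris) for metabolic stability; a higher number here means that the compound lasts longer, a lower number that the compound disappears faster. Compound 3 gives only a limit, > 0.5 h, and not a number. Compound 1 `N#Cc1ccc(NCCNc2ncc(-c3ncc[nH]3)c(-c3ccc(Cl)cc3Cl)n2)nc1` also gives only a limit, > 0.5 h. Compound 2 `FC(F)(F)c1ccc(NCCNc2ncc(-c3ncc[nH]3)c(-c3ccc(Cl)cc3Cl)n2)nc1` likewise gives only a limit, > 0.5 h. The whole series therefore stands at the limit of > 0.5 h in this assay, at which 3 of the 3 values shown sit, and compound 3 cannot be ranked against the others.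

Compound 4 `Nc1nc(NCCNc2ncc(-c3ncc[nH]3)c(-c3ccc(F)cc3F)n2)ccc1[N+](=O)[O-]` differs from compound 3 by a single change: 2,4-difluorophenyl in place of 4-chlorophenyl on an aromatic carbon. For the measured compounds named here, the only measured step is a step that the two limits leave unreadable from compound 1 to compound 2. It concerns trifluoromethyl in place of cyano, a different change, and offers no size to carry over. Going by the values given here, no measured step covers 2,4-difluorophenyl in place of 4-chlorophenyl, so no direction is assigned in this assay and no shift beyond the scatter is expected. The expected step is a step that the limit leaves unreadable from compound 3 to compound 4. For compound 4 the half-life is estimated at 0.7 h, with an expected range from 0.35 h to 1.5 h, and the reading may well be a limit again.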

Compound 4, half-life: > 0.5 h
Compound 4 ended at the assay's limit; the forecaster's own chance of this, stated with the estimate: 75%; the middle value lies beyond the limit too.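

In this assay compound 4 gives > 0.5 h, a limit and not a number. For the compounds shown here, compound 3 also gives only a limit, so no step between compound 3 and compound 4 can be read. The compounds shown leave open the actual half-life of each compound and whether 2,4-difluorophenyl in place of 4-chlorophenyl shifts it.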